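This account rests on a few compounds, and the source may have more. Where it says the series, first, only, none or still open, it means among the compounds named here.

In an assay on HEK293 cells for agonist activity at Toll-like receptor 8 (Homo sapiens), read by reporter gene assay (on this read-out lower numbers stand for an effect already at smaller amounts and higher numbers for an effect only at larger amounts of compound), three compounds of this series have already been run. Compound 1 `CCCCC1(O)C(N)=Nc2ccccc21` carries a pentyl chain on a ring carbon together with a hydroxy group, and in this assay compound 1 is reported as "not active" (no number reported). Compound 2 `CCCCCn1c(N)nc2cccc(C)c21` has the pentyl chain on a ring nitrogen and a methyl group on the aromatic ring, and in this assay compound 2 gives 6610 nM. Compound 3 `CCCCCn1c(N)nc2c(Br)cccc21` keeps the same core and chain but carries a bromo group on the aromatic ring, and in this assay compound 3 is reported as "not active" (no number reported). Compound 3 therefore stands without a number, as does compound 1, so that only compound 2 supplies a measured concentration among the three.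

Compound 4 `CCCCCn1c(N)nc2c(O)cccc21` is the next member. It differs from compound 3 by a single change: hydroxy in place of bromo on an aromatic carbon. Within the data shown here, no pair of measured compounds separated by a single change is available to show how large such a swap tends to move the read-out, and compound 3 itself has no number to start from. The expectation for compound 4 in this assay can only be framed loosely around the one number shown, that of compound 2, with a wide range and a real chance that no number is returned. Compound 4 is expected to give about 8000 nM, within 1500 nM to 40000 nM.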

Compound 4, half-maximal effective concentration: 5010 nM
Compound 4: the middle estimate sits 1.6-fold (0.20 log units) above what was measured; the range from low to high includes it.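

No step can be read from compound 3 to compound 4: in this assay compound 3 stands as "not active" (no number reported) and so gives hydroxy in place of bromo no number to start from. Nothing shown here helps explain the result. The compounds shown leave open how far one change on the aromatic ring moves this read-out.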